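Notes on the step from compound 3 to compound 4

A few compounds are considered here, and "the series" means these few. Any claim that something is new, unique, unknown or untested is made for them only; others in the source may bear on it.

In an ADME assay on microsomes from liver (Homo sapiens) for metabolic stability, read by LC-MS, using NADPH, with stated times of 5 min and 30 min, tested at 1 uM (on this read-out higher numbers stand for fast clearance and lower numbers for slow clearance), compound 1 (`Cn1nccc1-c1cnc(NCc2c(F)ccc3c2CCO3)c2cn[nH]c(=O)c12`) gives 14 mL.min-1.g-1, compound 2 (`O=C1CCCN1c1cnc(NCc2c(F)ccc3c2CCO3)c2cn[nH]c(=O)c12`) gives 23 mL.min-1.g-1 and compound 3 (`CN(C)C(=O)c1cc(-c2cnc(NCc3c(F)ccc4c3CCO4)c3cn[nH]c(=O)c23)n(C)n1`) gives 21 mL.min-1.g-1. Compound 3 therefore stands within the scatter of both other compounds, and the three values show no order among them.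

Compound 4 (`CN(c1ccn(C)n1)c1cnc(NCc2c(F)ccc3c2CCO3)c2cn[nH]c(=O)c12`) has not yet been measured. It carries methyl(1-methyl-1H-pyrazol-3-yl)amino in place of 3-(dimethylcarbamoyl)-1-methyl-1H-pyrazol-5-yl on an aromatic carbon.

Among the measured compounds shown here, three measured steps bear on this change. Two exchange the group on that aromatic carbon, a 1.6-fold higher number from compound 1 to compound 2 (0.22 log units; within the scatter) and a 1.1-fold lower number from compound 2 to compound 3 (0.04 log units; within the scatter), while the third adds dimethylcarbamoyl, a 1.5-fold higher number from compound 1 to compound 3 (0.18 log units; within the scatter). All three stay within the scatter, so no step beyond the scatter is expected in this assay, and no direction can be called. For the measured compounds named here, no measured compound carries methyl(1-methyl-1H-pyrazol-3-yl)amino, so the expectation rests on these three steps alone and its range stays wide.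

For compound 4 the estimated step is a 1.1-fold lower number from compound 3 to compound 4 (0.02 log units; within the scatter). For compound 4 the estimated value is 20 mL.min-1.g-1, with an expected range from 10 mL.min-1.g-1 to 40 mL.min-1.g-1.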

Compound 4, intrinsic clearance in microsomes: 62 mL.min-1.g-1
Estimate against measurement, compound 4: 3.1-fold (0.49 log units) below; measured number outside the range, above it.
By their numbers in this assay, from the lowest: compounds 1, 3 and 2 (each within the scatter of the next); then compound 4.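

In this assay, among the compounds shown here, this aromatic carbon, two atoms from the ring nitrogen, no longer looks indifferent to its group: methyl(1-methyl-1H-pyrazol-3-yl)amino brings a 3.0-fold higher number from compound 3 to compound 4 (0.47 log units; beyond the scatter) and a 2.7-fold higher number from compound 2 to compound 4 (0.43 log units; beyond the scatter) as well as a 4.4-fold higher number from compound 1 to compound 4 (0.65 log units; beyond the scatter) and so gives the first steps at this place beyond the scatter. Compound 4 stands apart from all three earlier compounds, which remain within the scatter of one another, so the earlier flat picture holds only for the groups in compounds 1, 2 and 3. The entering and leaving groups each hold a five-membered aromatic ring with 2 hetero atoms and have equal hydrogen-bond donor and acceptor counts, so these counts do not separate compound 3 from compound 4, and no measurement at hand explains the rise.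

The compounds shown do not tell whether the higher number belongs to the methyl on the linking nitrogen, to the linking amine itself or to the attached pyrazole. On these data alone, a secondary amine bearing the same pyrazole and a plain dimethylamino group would each separate these parts, and both remain open here.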